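From a Limit Back Toward Measurable Cytotoxicity

A few compounds are considered here, and "the series" means these few. Any claim that something is new, unique, unknown or untested is made for them only; others in the source may bear on it.

Compound 1 `CN(C)CCn1cnnc1-c1cc(Oc2ccc(NC(=O)N/N=C/c3ccc(F)cc3Cl)cc2F)ccn1`: 1210 nM in a functional assay on U-87MG ATCC cells (Homo sapiens) for cytotoxicity, read by MTT assay, with a stated time of 72 h; a higher number here means a weaker inhibitor, a lower number a stronger inhibitor
Compound 2 `CN(C)CCn1cnnc1-c1cc(Oc2ccc(NC(=O)N/N=C/c3ccc(Cl)cc3)cc2F)ccn1`: 1370 nM
Compound 3 `CN(C)CCn1cnnc1-c1cc(Oc2ccc(NC(=O)N/N=C/c3ccc(O)c(F)c3)cc2F)ccn1`: > 100000 nM, which is a limit of the assay and not a number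

Compound 3 thus stands at the weak end of the three, and its value tells only that it sits at the limit of > 100000 nM in this assay, at which 1 of the 3 values shown sits. Compound 4 `CN(C)CCn1cnnc1-c1cc(Oc2ccc(NC(=O)N/N=C/c3ccccc3)cc2F)ccn1` differs from it by phenyl in place of 3-fluoro-4-hydroxyphenyl on a carbon with a double bond to nitrogen. Going by the values given here, two measured steps bear on this change: an at least 82-fold higher number from compound 1 to compound 3 (1.91 log units; beyond the scatter) and an at least 72-fold higher number from compound 2 to compound 3 (1.86 log units; beyond the scatter), both large and beyond the scatter, each arriving at the limit. The change to compound 4 undoes that kind of move, so a large step downward in this assay is expected. Compound 4 is therefore estimated at about 2500 nM, within 800 nM to 12000 nM, an expected step of an at least 40-fold lower number from compound 3 to compound 4 (1.60 log units; beyond the scatter).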

Compound 4, half-maximal inhibitory concentration: 2250 nM
Compound 4: middle estimate off by 1.1-fold (0.05 log units), on the high side, and the stated range covers the measured number.
By their numbers in this assay, from the lowest: compounds 1, 2 and 4 (each within the scatter of the next). At a limit, above all of these: compound 3.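

Plain phenyl on this carbon gives an at least 44-fold lower number from compound 3 to compound 4 (1.64 log units; beyond the scatter), so an unsubstituted ring already returns a measurable number. The value of compound 3 is a limit of the assay, so that step is only a bound. Halogens are not required for this level of cytotoxicity: the results show a 1.6-fold higher number from compound 2 to compound 4 (0.22 log units; within the scatter) and a 1.9-fold higher number from compound 1 to compound 4 (0.27 log units; within the scatter), so chloro and fluoro make no readable difference among these three.

The compounds shown do not separate the effect of the hydroxy group in compound 3 from that of its fluoro. On these data alone, how a methoxy group, an amine or a carboxylic acid on this phenyl would read also remains open.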